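This account rests on a few compounds, and the source may have more. Where it says the series, first, only, none or still open, it means among the compounds named here.

The set consists of four nucleoside analogues examined in an ADME assay on BJ cells (Homo sapiens), read by MTT assay, with a stated time of 72 h; a lower number here means a stronger inhibitor, a higher number a weaker inhibitor. Compound 3 `C#Cc1cn([C@@H]2O[C@H](CO)[C@@H](O)[C@H]2O)c2ncnc(OC)c12` carries a methoxy group on its core, and in this assay compound 3 gives 98400 nM. Compound 1 `C#Cc1cn([C@@H]2O[C@H](CO)[C@@H](O)[C@H]2O)c2nc(N)nc(OC)c12` differs from it by one change, (amino in place of hydrogen on an aromatic carbon). For compound 1 the result in this assay is a limit of the assay, > 100000 nM. The step of an at least 1.0-fold higher number from compound 3 to compound 1 (0.00 log units; that floor lies within the scatter) thus brought no lower number, and this rests on (the limit of > 100000 nM in this assay, at which 1 of the 3 values shown sits).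

Compound 2 `O=c1[nH]cnc2c1c(-c1cc3ccccc3o1)cn2[C@@H]1O[C@H](CO)[C@@H](O)[C@H]1O` is built on a different core; the difference between the two cores is not broken down here. In this assay compound 2 gives 62700 nM, a number that lies within the scatter of the number for compound 3, so the two cannot be ordered.

Compound 4 `Nc1nc2c(c(-c3cc4ccccc4o3)cn2[C@@H]2O[C@H](CO)[C@@H](O)[C@H]2O)c(=O)[nH]1` has not yet been measured. It differs from compound 2 by amino in place of hydrogen on an aromatic carbon. This is the same kind of change as that from compound 3 to compound 1, though the surroundings differ: in compound 3 the amino enters meta to a methoxy group (2 heavy atoms), whereas in compound 2 it enters meta to a group of 1 heavy atom. Because the earlier change gave an at least 1.0-fold higher number from compound 3 to compound 1 (0.00 log units; that floor lies within the scatter), a step of similar size, within the scatter, is expected here. The step that this estimate means, a 1.4-fold higher number from compound 2 to compound 4 (0.13 log units; within the scatter), is expected to be small. Compound 4 is expected to give about 85000 nM, between 40000 nM and 200000 nM.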

Compound 4, half-maximal inhibitory concentration: > 100000 nM
Compound 4 gave a limit, no number (the forecaster's own chance of this, stated with the estimate: 35%); middle value at least 1.1-fold (0.07 log units) away from the limit.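

In this assay compound 4 gives > 100000 nM, which is a limit of the assay and not a number. Amino in place of hydrogen on an aromatic carbon, here between two ring nitrogen atoms, gives an at least 1.5-fold higher number from compound 2 to compound 4 (0.20 log units; that floor lies within the scatter), and set beside the earlier case the change on the two cores reads as follows: the same change on two cores in this assay, an at least 1.0-fold higher number (0.00 log units; that floor lies within the scatter) from compound 3 to compound 1 and an at least 1.5-fold higher number (0.20 log units; that floor lies within the scatter) from compound 2 to compound 4; the limit leaves it open whether they differ The change thus brought no lower number on either core, but this does not show that it carries over with the same size, since neither step has a known end point and both readings rest on the same limit: the limit of > 100000 nM in this assay, at which 2 of the 4 values shown sit.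

The compounds shown leave open what the amino group does on a core where the product stays clear of that limit, so that the step could be read as a number. They also leave open how a different group in the same place, such as a dimethylamino group, a hydroxyl group or a chlorine atom, would read in this assay.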